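The source may report more compounds than this note shows. Statements on the series, on what has been measured and on what is new or still open speak of the compounds shown alone.

Of the compounds shown here, two built on a shared core have been measured so far. Compound 1 `CCOc1nc(-c2cc3ccccc3o2)cc(-c2ccccc2)c1C#N` carries an ethoxy group, a cyano group and a phenyl ring on that core. In a functional assay on aorta (strain Wistar) for inhibition, with Thoracic aorta (Rattus norvegicus) as the target (on this read-out lower numbers stand for stronger inhibition and higher numbers for weaker inhibition), compound 1 gives 310000 nM, the highest of the two numbers at hand. Compound 2 `COc1ccc(-c2cc(-c3cc4ccccc4o3)nc(OC)c2C#N)cc1` differs from it at more than one place, and in this assay compound 2 gives 262000 nM. The gap between these two values lies within the usual scatter of such measurements, so the two compounds cannot be told apart on these numbers; both are very weak inhibitors.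

Compound 3 `CCOc1nc(-c2cc3ccccc3o2)cc(-c2cccs2)c1C#N` is the next compound, not yet measured. It differs from compound 1 in a single place: thiophen-2-yl in place of phenyl on an aromatic carbon. Among the compounds with values here, no measured pair shows what this exchange does, so the only guide is the two weak values already seen. The step of a 1.1-fold lower number from compound 1 to compound 3 (0.04 log units; within the scatter) is therefore expected to stay within the scatter, with no direction favoured. For compound 3 the estimate in this assay is 280000 nM, within a range from 120000 nM to 650000 nM.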

Compound 3, half-maximal inhibitory concentration: 308000 nM
Compound 3: middle estimate off by 1.1-fold (0.04 log units), on the low side; low and high end bracket the measured number.
By their numbers in this assay, from the lowest: compounds 2, 3 and 1 (each within the scatter of the next).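

Within the data shown here, compound 1 and compound 3 differ in one place only, so this is the first clean look at the position opposite the ring nitrogen. Exchanging phenyl, a six-membered carbon ring, for thiophen-2-yl, a five-membered ring holding one sulfur, gives a 1.0-fold lower number from compound 1 to compound 3 (0.00 log units; within the scatter) in this assay, and the two compounds cannot be told apart. At this position, then, the change in ring size and the added sulfur leave no detectable mark on a very weak inhibitor, and nothing at hand explains why this should be so.

As far as these compounds go, both groups at this position are aromatic rings, so it remains open whether something quite different there, such as an amine, a carboxylic acid or a longer alkyl chain, would give a clearly different number. From the compounds shown here alone, the ethoxy group also remains untested on its own, as compound 2 differs from compound 1 at more than one place and so cannot show what that group contributes.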